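A few compounds are considered here, and "the series" means these few. Any claim that something is new, unique, unknown or untested is made for them only; others in the source may bear on it.

Measured compounds:
Compound 1, `O=S(=O)(c1cc(Cl)cc(Cl)c1)c1cnc2c(F)cccc2c1-c1cccc(Cl)c1`, gives 1.2 mL/min in an ADME assay on microsomes from liver (Homo sapiens) for metabolic stability, tested at 2.5 uM; on this read-out higher numbers stand for fast clearance and lower numbers for slow clearance.
Compound 2, `O=S(=O)(c1cc(Cl)cc(Cl)c1)c1cnc2c(F)cccc2c1-c1ccc(F)cc1`, gives 1.01 mL/min in this assay.
Compound 3, `COc1cccc(-c2c(S(=O)(=O)c3cc(Cl)cc(Cl)c3)cnc3c(F)cccc23)c1`, gives 2.31 mL/min in this assay.

All three share one core and differ only in the aromatic group attached to that core. The step of a 1.2-fold lower number from compound 1 to compound 2 (0.07 log units; within the scatter) is within the scatter, so compound 1 and compound 2 cannot be told apart on this read-out. Among the compounds with values here, the step of a 2.3-fold higher number from compound 2 to compound 3 (0.36 log units; beyond the scatter) is modest but beyond the scatter, so compound 2 sits at the slow-clearance end of this small set, with compound 3 the one compound clearly apart from it.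

Compound 4, `O=S(=O)(c1ccc(F)c(F)c1)c1cnc2c(F)cccc2c1-c1ccc(F)cc1`, has not yet been measured. It differs from compound 2 in one place: 3,4-difluorophenyl in place of 3,5-dichlorophenyl on a sulfonyl sulfur. Within the data shown here, every measured step changes the aromatic group on the core carbon; none of them touches the group on the sulfonyl sulfur, so no measured step bears directly on this change. Among the measured compounds shown here, the measured steps were all small, the largest being a 2.3-fold higher number from compound 2 to compound 3 (0.36 log units; beyond the scatter), and that is the only guide available. Compound 4 is therefore expected to give a number close to that of compound 2, with a step of a 1.1-fold higher number from compound 2 to compound 4 (0.04 log units; within the scatter) that need not be beyond the scatter. The estimate for compound 4 in this assay is 1.1 mL/min, with a range from 0.5 mL/min to 2.5 mL/min.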

Compound 4, intrinsic clearance in a liver preparation (reported as CLH), per the amount of preparation that the assay uses: 0.78 mL/min
Compound 4: middle estimate off by 1.4-fold (0.15 log units), on the high side; low and high end bracket the measured number.
By their numbers in this assay, from the lowest: compounds 4, 2, 1 and 3 (each within the scatter of the next, the first and the last beyond it).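

Within the data shown here, until now, only the aromatic group on the shared core had changed, so this is the first view of the group on the sulfonyl sulfur. In this assay, putting 3,4-difluorophenyl in place of 3,5-dichlorophenyl on that sulfur gives a 1.3-fold lower number from compound 2 to compound 4 (0.11 log units; within the scatter) and so stays within the scatter: in this one pair, a ring carrying two chlorine atoms gives way to a ring carrying two fluorine atoms with no difference that this read-out can resolve. Nothing among the data shown offers an explanation for this result.

As far as these compounds go, both groups seen on the sulfonyl sulfur are phenyl rings with two halogen atoms, so it remains open how this read-out would respond to a very different group there, such as a pyridine ring, a plain methyl or a morpholine ring. It is also open whether the same swap would behave alike with 3-chlorophenyl or 3-methoxyphenyl on the core, as the one pair shown carries 4-fluorophenyl there.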